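Methoxy for fluoro on the thioether arm

A few compounds are considered here, and "the series" means these few. Any claim that something is new, unique, unknown or untested is made for them only; others in the source may bear on it.

Working notes on a small set sharing one core. Among the compounds with values here, compound 1 `Nc1cc(N)c2nc(-c3ccccc3)c(NCc3ccc(Cl)c(Cl)c3)nc2c1` is the only member with a number: in a functional assay on SN12C cells (Homo sapiens) for inhibition, read by sulforhodamine B assay, with a stated time of 48 h (a lower number here means a stronger inhibitor of growth, a higher number a weaker inhibitor of growth), compound 1 gives 24000 nM. Compound 2 `Nc1cc(N)c2nc(-c3ccccc3)c(Sc3ccc(F)cc3)nc2c1` carries a (4-fluorophenyl)sulfanyl group on the core. In this assay compound 2 gives only a limit, < 100000 nM, not a number. Compound 3 `CCOC(=O)[C@H](CCC(=O)O)NC(=O)c1ccc(CNc2nc3cc(N)cc(N)c3nc2-c2ccccc2)cc1` likewise returns only a limit in this assay, < 100000 nM. Within the data shown here, compound 2 therefore stands at the limit of < 100000 nM in this assay, at which 2 of the 3 values shown sit, so its position among the three cannot be placed more closely, and no step between two measured numbers exists to guide this pair.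

Compound 4 `COc1ccc(Sc2nc3cc(N)cc(N)c3nc2-c2ccccc2)cc1` differs from compound 2 in one place: methoxy in place of fluoro on an aromatic carbon. Among the measured compounds shown here, this change has no measured counterpart in the set. The expectation for this assay is a step of no size beyond the usual scatter, in either direction: a step that the limit leaves unreadable from compound 2 to compound 4 is the expected step. Compound 4 is estimated at 60000 nM in this assay, within 15000 nM to 100000 nM, and a further limit rather than a number is expected to remain the likelier outcome.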

Compound 4, concentration for total growth inhibition: 24000 nM
Estimate against measurement, compound 4: 2.5-fold (0.40 log units) above, within the range that was stated.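

No step from compound 2 to compound 4 can be read, because compound 2 has only a limit and not a number: the limit of < 100000 nM in this assay, at which 2 of the 4 values shown sit.

The compounds shown leave open whether, and in which direction, going from (4-fluorophenyl)sulfanyl to (4-methoxyphenyl)sulfanyl shifts the read-out in this assay at all.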